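A Third Phenyl Ether Tested Where Two Sat at the Limit

A few compounds are considered here, and "the series" means these few. Any claim that something is new, unique, unknown or untested is made for them only; others in the source may bear on it.

Three compounds have been measured in an assay for inhibition of Polyunsaturated fatty acid 5-lipoxygenase (Homo sapiens), read by HPLC, with a stated time of 10 min (on this read-out lower numbers stand for stronger inhibition and higher numbers for weaker inhibition), and each of them reached only a limit of the assay rather than a number:

Compound 1 `CCCCC(Sc1ccc(OCCCOc2ccc3ncccc3c2)cc1)C(=O)OCC` gave > 10000 nM.
Compound 2 `CCCCC(Sc1ccc(OCCCOc2ccc(C)cc2)cc1)C(=O)O` gave > 10000 nM.
Compound 3 `CCCCC(Sc1ccc(OCCCOc2cccc(C)c2)cc1)C(=O)O` gave > 10000 nM.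

So compound 3 stands at the limit of this assay, and the other two values shown stand at the same limit, as the limit of > 10000 nM in this assay, at which 3 of the 3 values shown sit, records. Among the compounds with values here, the only step between compounds that differ in one place, a step that the two limits leave unreadable from compound 2 to compound 3, is therefore unreadable, as neither end of it is a number.

Compound 4 `CCCCC(Sc1ccc(OCCCOc2ccc(Cl)cc2OC)cc1)C(=O)O` is the next compound to be measured in this assay. It differs from compound 3 in one place: 4-chloro-2-methoxyphenyl in place of 3-methylphenyl on an oxygen on a saturated carbon.

Within the data shown here, no measured step speaks readably to this change, so there is nothing to suggest that compound 4 would move off the limit in this assay. The estimate for compound 4 is 15000 nM, between 5000 nM and 50000 nM, meaning an expected step that the limit leaves unreadable from compound 3 to compound 4.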

Compound 4, half-maximal inhibitory concentration: > 10000 nM
Compound 4: a limit, no number (the forecaster's own chance of this, stated with the estimate: 75%); the middle value does not contradict the limit.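

In this assay compound 4 gives > 10000 nM, which is a limit and not a number. Steps to compound 4 from compound 2 and compound 3 therefore cannot be read. The compounds shown leave open whether any change to this shared core would give a measurable value.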